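Lengthening a side chain on two closely related cores

This account rests on a few compounds, and the source may have more. Where it says the series, first, only, none or still open, it means among the compounds named here.

Measured so far:
compound 1 `C=CCn1ncc2c(C)nc(CC)n2c1=O`: > 48000 nM
compound 2 `C=CCn1ncc2c(CC)ncn2c1=O`: > 48000 nM
compound 3 `C=CCn1ncc2c(C)nc(CCC)n2c1=O`: 40000 nM

All three were tested in a functional assay for inhibition, with Homo sapiens as the target; a lower number here means a stronger inhibitor, a higher number a weaker inhibitor. For compound 1 this assay gave only a limit, > 48000 nM. For compound 2 it likewise gave only a limit, > 48000 nM. Within the data shown here, compound 3 is the one member with a number, 40000 nM.

Compound 3 comes from compound 1 by a single change, (methyl in place of hydrogen on a saturated chain carbon, two bonds along the chain from an aromatic carbon). Among the measured compounds shown here, the step that went with it is an at least 1.2-fold lower number from compound 1 to compound 3 (0.07 log units; that floor lies within the scatter); because of the limit of > 48000 nM in this assay, at which 2 of the 3 values shown sit, its true size cannot be fixed, and what is known is only that the number moved off the limit by a small amount.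

Compound 2 shares most of its structure with compound 1, but the difference between the two cores is not broken down here. The compound still to be measured is compound 4 `C=CCn1ncc2c(CCC)ncn2c1=O`, which arises from compound 2 by the same change, (methyl in place of hydrogen on a saturated chain carbon, two bonds along the chain from an aromatic carbon). The place of the change is the same in both pairs.

Given that the measured instance barely moved the value, compound 4 is expected to sit near 50000 nM. The step that the limit leaves unreadable from compound 2 to compound 4 is expected to be about as small as the step seen before. This expectation rests on an at least 1.2-fold lower number from compound 1 to compound 3 (0.07 log units; that floor lies within the scatter) and on the fact that compound 2 itself is known only as a limit, so a reading at the limit again would not be surprising.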

Compound 4, half-maximal inhibitory concentration: > 48000 nM
Compound 4: a limit, no number; the forecaster's own chance of this, stated with the estimate: 60%; the middle value lies beyond the limit too.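

In this assay compound 4 gives only a limit, > 48000 nM, and not a number. The step from compound 2 to compound 4 therefore cannot be read, because both compounds are known only as limits: the limit of > 48000 nM in this assay, at which 3 of the 4 values shown sit.

The compounds shown leave open whether lengthening ethyl to propyl changes the potency of the core of compound 2 at all.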